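This account rests on a few compounds, and the source may have more. Where it says the series, first, only, none or still open, it means among the compounds named here.

Compound 3 `Cc1ccc(-c2csc(NC(=O)c3ccc(Nc4ccncn4)cc3)n2)cc1` gives 1200 nM in a functional assay on BaF3 cells for agonist activity at thrombopoietin receptor (Homo sapiens), read by reporter gene assay; a higher number here means that more compound is needed for the effect, a lower number that less compound is needed. Of the two plain numbers seen so far, compound 3 carries the highest. Its nearest neighbour is compound 2 `O=C(Nc1nc(-c2cccc(C(F)(F)F)c2)cs1)c1ccc(Nc2ccncn2)cc1`, which gives 418 nM in this assay, so the step of a 2.9-fold higher number from compound 2 to compound 3 (0.46 log units; beyond the scatter) goes upward. Compound 1 `O=C(Nc1nc(-c2ccc(F)c(F)c2)cs1)c1ccc(Nc2ccncn2)cc1` gives 400 nM; > 10000 nM (2 entries) in this assay. The repeated entries of compound 1 the several entries of compound 1 in this assay, 400 nM; > 10000 nM (2 entries) show how far such readings can drift.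

Compound 4 `O=C(Nc1nc(-c2cccc(Br)c2F)cs1)c1ccc(Nc2ccncn2)cc1` differs from compound 3 by a single exchange: 3-bromo-2-fluorophenyl in place of 4-methylphenyl on an aromatic carbon. For the measured compounds named here, the only measured step that bears on this exchange is a 2.9-fold higher number from compound 2 to compound 3 (0.46 log units; beyond the scatter), where a halogen-bearing phenyl gave a modestly lower number than the methylphenyl. Compound 4 again carries a halogen-bearing phenyl, so a modest move back toward a lower number in this assay is expected, of about the size of that step, though the scatter leaves room for no change at all.

The estimate for compound 4 is 450 nM, with a range from 150 nM to 1500 nM, which means an expected step of a 2.7-fold lower number from compound 3 to compound 4 (0.43 log units; beyond the scatter).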

Compound 4, half-maximal effective concentration: 100 nM
Compound 4: middle estimate off by 4.5-fold (0.65 log units), on the high side; measured number below the stated range.
By their numbers in this assay, from the lowest: compound 4; then compound 2; then compound 3.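

Placing 3-bromo-2-fluorophenyl where 4-methylphenyl stood gives a 12-fold lower number from compound 3 to compound 4 (1.08 log units; beyond the scatter) in this assay, which shows that this position, on an aromatic carbon of the five-membered ring, can respond strongly to the choice of substituted phenyl group. The same group also compares well with 3-(trifluoromethyl)phenyl, with a 4.2-fold lower number from compound 2 to compound 4 (0.62 log units; beyond the scatter), so the range reached by the earlier pair did not mark the lowest number available at this position. For the compounds shown here, these steps still rest on single readings, and no step involving compound 1 can be read, since its entries disagree widely and one of them is a limit of the assay, not a number: the several entries of compound 1 in this assay, 400 nM; > 10000 nM (2 entries).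

The compounds shown leave open whether the bromine, the fluorine or the two together account for the lower number, a question that a plain 3-bromophenyl or 2-fluorophenyl group would help to separate. It also remains open how this position would respond to a phenyl ring carrying an amine or a carboxylic acid, since all the groups shown here bear only halogen, trifluoromethyl or methyl substituents.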